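Fluoro to Propoxy on the Pyridine-Bearing Biaryl Amide

This account rests on a few compounds, and the source may have more. Where it says the series, first, only, none or still open, it means among the compounds named here.

Compound 1: `CC(C)(C)c1ccc(NC(=O)c2ccc(-c3ccccn3)cc2)cc1` — 8 nM
Compound 2: `CC(C)(C)c1ccc(NC(=O)c2ccc(-c3ncccc3F)cc2)cc1` — 1 nM

The two measured compounds share one core and differ in a single position. In a functional assay for antagonist activity at transient receptor potential cation channel subfamily V member 1 (Rattus norvegicus) (on this read-out lower numbers stand for stronger inhibition and higher numbers for weaker inhibition), compound 1 gives 8 nM, and compound 2 gives 1 nM. Compound 2 thus stands at the lowest of the two numbers; the change an 8.0-fold lower number from compound 1 to compound 2 (0.90 log units; beyond the scatter) shows that fluoro in place of hydrogen on an aromatic carbon gave a clear gain.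

Compound 3 is `CCCOc1cccnc1-c1ccc(C(=O)Nc2ccc(C(C)(C)C)cc2)cc1`. Relative to compound 2 the change is propoxy in place of fluoro on an aromatic carbon: a propoxy chain now occupies the position that held the fluorine, on an aromatic carbon of a six-membered aromatic ring with 1 nitrogen, two atoms from the ring nitrogen.

Among the compounds with values here, only one measured step touches this position, the step from compound 1 to compound 2, and it concerns fluoro against hydrogen, not a propoxy chain. Nothing measured here speaks to a larger group at this place. A moderate loss is therefore expected for compound 3, a 3.0-fold higher number from compound 2 to compound 3 (0.48 log units; beyond the scatter), with wide uncertainty. The estimate for compound 3 in this assay is 3 nM, within 0.5 nM to 20 nM.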

Compound 3, half-maximal inhibitory concentration: 20 nM
Beside the measured number, compound 3's estimate is 6.7-fold (0.82 log units) below it, and the stated range covers the measured number.
By their numbers in this assay, from the lowest: compound 2; then compound 1; then compound 3.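

Within the data shown here, replacing the fluoro with the propoxy chain gives a far larger change than the earlier gain from fluoro: in this assay the result is a 20-fold higher number from compound 2 to compound 3 (1.30 log units; beyond the scatter), a large step at a position where the only earlier step was modest. The chain also falls short of plain hydrogen, with a 2.5-fold higher number from compound 1 to compound 3 (0.40 log units; beyond the scatter), so this place does not reward every group put on it, and among these three compounds the order from lowest number to highest runs fluoro, hydrogen, propoxy. Nothing available here gives a reason for this loss of inhibition.

From the compounds shown here alone, what remains open is where between the single fluorine atom and the propoxy chain the loss sets in, and whether it follows the length of the chain: a methoxy or an ethoxy group at the same place would show this, and a butoxy chain would extend the series the other way. Going by these compounds, it is also open whether the oxygen link itself matters, which a plain propyl chain or an amine at this place could help to separate from the effect of the chain.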